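Lengthening the Ketone Side Chain in Glutamate Receptor Modulators

The source may report more compounds than this note shows. Statements on the series, on what has been measured and on what is new or still open speak of the compounds shown alone.

Measured so far:
- compound 1, `Cc1c(OCCCCOc2ccc(F)c(C(=O)O)c2)ccc(C(=O)CC(C)(C)C)c1O`, gives 94.6%
- compound 2, `Cc1c(OCCCCOc2ccc(C(=O)O)cc2F)ccc(C(=O)CC(C)C)c1O`, gives 85%
- compound 3, `Cc1c(OCCCCOc2ccc(F)c(C(=O)O)c2)ccc(C(=O)C(C)C)c1O`, gives 74.1%

These three compounds share one core and were tested in an assay on HEK293 cells for positive allosteric modulation of metabotropic glutamate receptor 2 (Rattus norvegicus), read by thallium flux, with a stated time of 2.5 min; a higher number here means a larger maximal response, a lower number a smaller maximal response. Compound 3 stands lowest of the three: compound 2 lies nearer to it, and compound 1 lies furthest above it, both gaps beyond the scatter. The step from compound 1 to compound 3 shows the effect of shrinking the group on the carbonyl carbon: a number 20.5 percentage points lower from compound 1 to compound 3 (beyond the scatter).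

Compound 4, `Cc1c(OCCCCOc2ccc(F)c(C(=O)O)c2)ccc(C(=O)CC(C)C)c1O`, is the next compound and has not yet been measured. It differs from compound 3 in one place: isobutyl in place of isopropyl on a carbonyl carbon. For the measured compounds named here, this is the only step in the set that bears on the move, and it ran downward when the group became smaller. Adding one carbon back is therefore expected to push the maximal response upward, by a modest amount, since compound 2 with the same isobutyl group and a fluorine in a different place gave 85%. Compound 4 is expected to give 85%, estimated between 72% and 97%, a step of a number 10.9 percentage points higher from compound 3 to compound 4 (beyond the scatter).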

Compound 4, largest response reached (reported as percent of maximum), in percent of the reference or control that the assay uses: 84.5%
Estimate against measurement, compound 4: 0.5 percentage points above; low and high end bracket the measured number.
By their numbers in this assay, from the lowest: compound 3; then compounds 4, 2 and 1 (each within the scatter of the next, the first and the last beyond it).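

On the carbonyl carbon, isobutyl in place of isopropyl gives a number 10.4 percentage points higher from compound 3 to compound 4 (beyond the scatter) in this assay, and hydrogen in place of methyl on the chain gives a number 10.1 percentage points lower from compound 1 to compound 4 (beyond the scatter), so with the 3-carboxy-4-fluorophenyl group held fixed, the maximal response climbs in two separate steps from isopropyl through isobutyl to neopentyl. With isobutyl held fixed, 3-carboxy-4-fluorophenyl in place of 4-carboxy-2-fluorophenyl gives a number 0.5 percentage points lower from compound 2 to compound 4 (within the scatter), so these two groups cannot be told apart here. Nothing available explains either trend.

Still open, on these data alone, is whether the climb continues with a longer chain such as n-hexyl, or with a ring such as cyclohexyl, on the carbonyl carbon. Also open, as far as these compounds go, is whether the two carboxy-fluorophenyl groups would still match alongside isopropyl or neopentyl.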